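Swapping the outer ring on a dichlorinated statin-like lactone

This account rests on a few compounds, and the source may have more. Where it says the series, first, only, none or still open, it means among the compounds named here.

Measured so far:
compound 1, `Cc1ccccc1-c1cc(Cl)cc(Cl)c1/C=C/[C@@H]1C[C@@H](O)CC(=O)O1`: 370 nM
compound 2, `O=C1C[C@H](O)CC(CCc2ccccc2-c2ccccc2)O1`: 44000 nM
compound 3, `Cc1cc(C)c(/C=C/[C@@H]2C[C@@H](O)CC(=O)O2)c(-c2cc(C)c(F)c(C)c2)c1`: 10 nM

In an assay for inhibition of 3-hydroxy-3-methylglutaryl-coenzyme A reductase (Rattus norvegicus) (a higher number here means a weaker inhibitor, a lower number a stronger inhibitor), compound 1 gives 370 nM, which places it second highest among the three numbers. Its nearest neighbour is compound 3, whose value of 10 nM lies lower by a margin beyond the scatter. Compound 2, with 44000 nM, sits far higher, again beyond the scatter. Compound 4, `Cc1cc(-c2cc(Cl)cc(Cl)c2/C=C/[C@@H]2C[C@@H](O)CC(=O)O2)ccc1F`, has not yet been measured in this assay. It differs from compound 1 in one place: 4-fluoro-3-methylphenyl in place of 2-methylphenyl on an aromatic carbon. Compound 4 shares a related ring with compound 3, yet the two differ in several other places, so the value of compound 3, 10 nM, is only a loose pointer. Among the measured compounds shown here, no single-change step between measured compounds exists to calibrate this swap, so the expectation rests on the overall spread. The step of a 2.5-fold lower number from compound 1 to compound 4 (0.39 log units; beyond the scatter) is expected to be moderate and toward a lower number. Compound 4 is estimated to give 150 nM, with a range from 40 nM to 600 nM.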

Compound 4, half-maximal inhibitory concentration: 29 nM
For compound 4 the middle estimate is 5.2-fold (0.71 log units) above the measured one, outside the stated range (below it).
By their numbers in this assay, from the lowest: compound 3; then compound 4; then compound 1; then compound 2.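

Changing only the outer ring, with 4-fluoro-3-methylphenyl in place of 2-methylphenyl, gives a 13-fold lower number from compound 1 to compound 4 (1.11 log units; beyond the scatter) in this assay, so this place on the shared core has a large effect on the number. This is the only single-change step among the compounds shown, and it is well beyond the usual scatter. The two rings differ both in the fluoro group and in where the methyl group sits, so the step belongs to the whole swap, and nothing available explains its size.

From the compounds shown here alone, how much of the step comes from the fluoro group and how much from the methyl group's new place remains open; simpler rings such as 3-methylphenyl and 4-fluorophenyl would help separate the two. Going by these compounds, whether a 4-chloro-3-methylphenyl ring or a methoxy-bearing phenyl ring would fit the same trend also remains unknown.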